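Extending the Alkyl Chain from Compound 2 to Compound 3

A few compounds are considered here, and "the series" means these few. Any claim that something is new, unique, unknown or untested is made for them only; others in the source may bear on it.

Measured in an assay on HEK-293T cells for inhibition of diacylglycerol lipase-alpha (Homo sapiens), read by colorimetric assay; a lower number here means a stronger inhibitor, a higher number a weaker inhibitor:
compound 1, `O=C(CCCCCCCCc1ccccc1)c1nc2ncccc2o1`: 3.63 nM
compound 2, `CCCCCCCCCC(=O)c1nc2ncccc2o1`: 74.1 nM

Of these two numbers, compound 2 gives the higher one. Compound 3, `CCCCCCCCCCCCCC(=O)c1nc2ncccc2o1`, differs from compound 2 by butyl in place of hydrogen on a saturated chain carbon, nine bonds along the chain from a carbonyl carbon. Within the data shown here, the only step on record, a 20-fold higher number from compound 1 to compound 2 (1.31 log units; beyond the scatter), bears on this change: replacing phenyl by methyl at the chain end cost a great deal. Because a 20-fold higher number from compound 1 to compound 2 (1.31 log units; beyond the scatter) was large and the entering butyl again puts more chain at that position, a moderate step toward a lower number is expected for compound 3, a 3.7-fold lower number from compound 2 to compound 3 (0.57 log units; beyond the scatter). Compound 3 is therefore estimated at 20 nM, ranging from 5 nM to 80 nM.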

Compound 3, half-maximal inhibitory concentration: 74.1 nM
Estimate against measurement, compound 3: 3.7-fold (0.57 log units) below; measured number inside the range.
By their numbers in this assay, from the lowest: compound 1; then compounds 2 and 3 (each within the scatter of the next).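

In this assay, butyl in place of hydrogen on a saturated chain carbon, nine bonds along the chain from a carbonyl carbon, gave no change at the digits printed from compound 2 to compound 3 (within the scatter), so this added saturated chain did nothing measurable at this position. Pentyl in place of phenyl gave a 20-fold higher number from compound 1 to compound 3 (1.31 log units; beyond the scatter), which shows that chain of this added length does not stand in for the phenyl of compound 1. Nothing on record explains either result. Still open, going by these compounds, is whether a chain longer than that of compound 3 would read differently. Also open, on these data alone, is how a carboxylic acid or an amine at the chain end would compare with phenyl.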